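The source may hold more compounds than are shown below. What is called first, only, known or untested is meant among the compounds shown, and "the series" means these compounds.

Measured so far in an assay on cells for antagonist activity at transient receptor potential cation channel subfamily V member 1 (Homo sapiens), read by FLIPR and calcium flux, with a stated time of 6 min; on this read-out lower numbers stand for stronger inhibition and higher numbers for weaker inhibition:
Compound 1 `CC(C(=O)NCc1ccc(C(C)(C)C)nc1N1CCCC1)c1ccc(NS(C)(=O)=O)c(F)c1` gives 1.2 nM.
Compound 2 `CC(C(=O)NCc1ccc(C(C)(C)C)nc1SC1CCCC1)c1ccc(NS(C)(=O)=O)c(F)c1` gives 2.5 nM.
Compound 3 `CC(C(=O)NCc1ccc(C(C)(C)C)cc1N1CCCC1)c1ccc(NS(C)(=O)=O)c(F)c1` gives 8.1 nM.

Compound 3 thus stands at the highest number of the three; the gap to compound 2 and the larger gap to compound 1 both lie beyond the usual scatter. Compound 4 `CC(C)COc1cc(C(C)(C)C)ccc1CNC(=O)C(C)c1ccc(NS(C)(=O)=O)c(F)c1` has not yet been measured. It differs from compound 3 in one place: isobutoxy in place of pyrrolidin-1-yl on an aromatic carbon — that is, isobutoxy in place of pyrrolidin-1-yl on an aromatic carbon of a six-membered aromatic ring of carbon only, ortho to a large group and meta to a tert-butyl group.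

Going by the values given here, no measured pair shows exactly this exchange. The nearest guide is a 2.1-fold higher number from compound 1 to compound 2 (0.32 log units; beyond the scatter), where the pyrrolidin-1-yl was likewise replaced on an aromatic carbon, there by cyclopentylsulfanyl, and the number rose modestly. On that basis a modest rise from compound 3 to compound 4 is expected in this assay, a 2.0-fold higher number from compound 3 to compound 4 (0.30 log units; within the scatter), with real uncertainty because the entering group here is a chain rather than a ring. Compound 4 is therefore estimated at 16 nM, within a range from 5 nM to 50 nM.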

Compound 4, inhibition constant: 2.1 nM
The estimate for compound 4 lay 7.6-fold (0.88 log units) above the measured number; the measured number lies below the stated range.
By their numbers in this assay, from the lowest: compounds 1, 4 and 2 (each within the scatter of the next, the first and the last beyond it); then compound 3.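

On the carbon-only aromatic ring, at the carbon ortho to a large group and meta to a tert-butyl group, isobutoxy in place of pyrrolidin-1-yl gave in this assay a 3.9-fold lower number from compound 3 to compound 4 (0.59 log units; beyond the scatter). For this pair, therefore, the ring of the leaving group was not needed for a low number: an open chain with the same heavy-atom count took its place, and the number fell. Replacing pyrrolidin-1-yl on an aromatic carbon thus has no single direction across these compounds, since the earlier exchange for cyclopentylsulfanyl gave a 2.1-fold higher number from compound 1 to compound 2 (0.32 log units; beyond the scatter), a step opposite in direction, although that exchange involved a different entering group on a different core, and no measurement shown here explains either step.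

The compounds shown leave open how a cyclopentyloxy group, a longer alkoxy chain or an open-chain diethylamino group would read at this carbon, which would help separate the effect of the ring from that of the linking atom. They also leave open whether isobutoxy would give a step of the same direction and size on the core of compound 1.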